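Methyl for Fluoro Ortho to the Lactam

A few compounds are considered here, and "the series" means these few. Any claim that something is new, unique, unknown or untested is made for them only; others in the source may bear on it.

Three compounds share a core: compound 1 `CCc1cc(=O)oc2c(C)c(OCc3nc(N)nc(Nc4ccc(C)cc4)n3)ccc12`, for which an assay on COS-7 cells for agonist activity at Free fatty acid receptor 1 (Homo sapiens), read by scintillation counting and inositol phosphate accumulation, with a stated time of 90 min (a higher number here means that more compound is needed for the effect, a lower number that less compound is needed), gives "not determined" (no result reported), compound 2 `Cc1ccc(Nc2nc(N)nc(COc3cccc(N4CCCC4=O)c3)n2)cc1Cl`, which in this assay gives 820 nM, and compound 3 `Cc1ccc(Nc2nc(N)nc(COc3cccc(N4CCCC4=O)c3F)n2)cc1Cl`, which gives 14100 nM. Among the compounds with values here, compound 3 thus stands highest of the two numbers; its nearest neighbour is compound 2, and the only measured step, a 17-fold higher number from compound 2 to compound 3 (1.24 log units; beyond the scatter), is large. Compound 4 `Cc1ccc(Nc2nc(N)nc(COc3cccc(N4CCCC4=O)c3C)n2)cc1Cl` differs from compound 3 by methyl in place of fluoro on an aromatic carbon. Within the data shown here, no measured step tells how methyl compares with fluoro at this position; the one step that bears on it shows that a change here from hydrogen mattered a great deal. Compound 4 is therefore expected near compound 3, at 12000 nM with a range of 2000 nM to 60000 nM, a step of a 1.2-fold lower number from compound 3 to compound 4 (0.07 log units; within the scatter) that is uncertain in direction.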

Compound 4, half-maximal effective concentration: 11100 nM
Beside the measured number, compound 4's estimate is 1.1-fold (0.03 log units) above it; the range from low to high includes it.
By their numbers in this assay, from the lowest: compound 2; then compounds 4 and 3 (each within the scatter of the next).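

In this assay, methyl and fluoro on this aromatic carbon, ortho to a 2-oxopyrrolidin-1-yl group, are not told apart, with a 1.3-fold lower number from compound 3 to compound 4 (0.10 log units; within the scatter). With methyl in place of hydrogen the result is a 14-fold higher number from compound 2 to compound 4 (1.13 log units; beyond the scatter), so the large step away from hydrogen is not confined to fluoro but appears with both groups. Nothing measured is offered that explains this.

Going by these compounds, whether a larger group here, such as methoxy or an amine, would follow the same course stays open. So does whether the same holds for either group elsewhere on this ring.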